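From a Cyclopropyl Ether to a Difluoromethyl Ether

The compounds below may be only part of what the source reports. "The series", "measured", "known", "first", "only" and "open" are said of these compounds alone.

Measured so far:
Compound 1, `CC(C)(NS(=O)(=O)c1cccc(OCC2CC2)c1)c1ccc(Cn2ccc(=O)[nH]c2=O)cc1`: 140 nM
Compound 2, `C[C@@H](NS(=O)(=O)c1ccc(Cn2ccc(=O)[nH]c2=O)cc1)c1cccc(OCC2CC2)c1`: 930 nM

In an assay on HeLa cells for inhibition of Deoxyuridine 5'-triphosphate nucleotidohydrolase, mitochondrial (Homo sapiens), read by crystal violet staining, with a stated time of 24 h (on this read-out higher numbers stand for an effect only at larger amounts of compound and lower numbers for an effect already at smaller amounts), compound 1 gives 140 nM. Compound 2 gives 930 nM, the higher of the two numbers, and its gap to compound 1 lies beyond the usual scatter. The two measured compounds differ in several places at once, so no single change has yet been followed on its own.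

Among the measured compounds shown here, compound 3, `C[C@@H](NS(=O)(=O)c1ccc(Cn2ccc(=O)[nH]c2=O)cc1)c1cccc(OCC(F)F)c1`, is the first such single step, from compound 2: difluoromethyl in place of cyclopropyl on a saturated chain carbon bound to an oxygen on an aromatic ring. For the measured compounds named here, no measured pair shows what this change does here, so the expectation rests on the change itself: the new group and the old one are alike in size and neither brings a donor or acceptor, so no step beyond the scatter is expected, perhaps a slight rise. Compound 3 is therefore expected to give 1200 nM, within a range from 500 nM to 3000 nM. The expected step in this assay is a 1.3-fold higher number from compound 2 to compound 3 (0.11 log units; within the scatter).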

Compound 3, half-maximal effective concentration: 610 nM
The estimate for compound 3 lay 2.0-fold (0.29 log units) above the measured number; the measured number falls inside the stated range.
By their numbers in this assay, from the lowest: compound 1; then compounds 3 and 2 (each within the scatter of the next).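

In this assay the result is a 1.5-fold lower number from compound 2 to compound 3 (0.18 log units; within the scatter) when difluoromethyl takes the place of cyclopropyl on a saturated chain carbon bound to an oxygen on an aromatic ring. Among the compounds shown here, this is the first single change that can be followed on its own, and it shows that, on the core of compound 2, the three-membered ring can give way to an open group with no step that stands out from repeat measurements. Nothing measured here speaks to why these two groups read alike.

Going by these compounds, it remains open whether a carboxylic acid, an amine or a longer chain at this place would shift the number beyond the scatter. Also open, on these data alone, is whether difluoromethyl would behave the same way on the core of compound 1, which differs from compound 2 in several places at once.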